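The source may hold more compounds than are shown below. What is called first, only, known or untested is meant among the compounds shown, and "the series" means these compounds.

Measured in a functional assay on HT-29 cells (Homo sapiens) for antiproliferative activity, read by MTT assay, with a stated time of 48 h; a higher number here means a weaker inhibitor of growth, a lower number a stronger inhibitor of growth:
compound 1 `CCCOC(=O)N1N=C(c2cccc(OC)c2)CC1c1cc(OC)c(OC)c(OC)c1`: > 10000 nM
compound 2 `COC(=O)N1N=C(c2ccc(OC)cc2)CC1c1cc(OC)c(OC)c(OC)c1`: 2550 nM
compound 3 `COC(=O)N1N=C(c2cccc(O)c2)CC1c1cc(OC)c(OC)c(OC)c1`: 1350 nM

Going by the values given here, compound 3 does not stand apart from the only other numeric value, the step being a 1.9-fold lower number from compound 2 to compound 3 (0.28 log units; within the scatter). Compound 4 `CCCOC(=O)N1N=C(c2cccc(O)c2)CC1c1cc(OC)c(OC)c(OC)c1` is compound 3 with one change: ethyl in place of hydrogen on a saturated chain carbon bound to an oxygen next to a carbonyl group, which reads as methoxycarbonyl to propoxycarbonyl. The measured step does not touch this place. Among the compounds with values here, the only guide is compound 1, which also carries propoxycarbonyl but differs elsewhere as well. Compound 1 gives > 10000 nM, a limit, so a higher number in this assay, beyond the scatter, is expected from this change. The expected step is a 3.3-fold higher number from compound 3 to compound 4 (0.52 log units; beyond the scatter). The estimate for compound 4 is 4500 nM, with an expected range of 1700 nM to 12000 nM.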

Compound 4, concentration for 50% growth inhibition: 15200 nM
Compound 4: the middle estimate sits 3.4-fold (0.53 log units) below what was measured; the measured number lies above the stated range.
By their numbers in this assay, from the lowest: compounds 3 and 2 (each within the scatter of the next); then compound 4.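

In this assay, with the 3-hydroxyphenyl group held fixed, methoxycarbonyl to propoxycarbonyl gives an 11-fold higher number from compound 3 to compound 4 (1.05 log units; beyond the scatter), the only reading of this change at one place among the compounds shown. Growth inhibition at this place is therefore sensitive to added chain length, a large effect set against the earlier step in the series, which stayed within the scatter. The step between compound 1 and compound 4 cannot be read, since compound 1 is a limit: the limit of > 10000 nM in this assay, at which 1 of the 4 values shown sits.

On these data alone, whether ethoxycarbonyl would fall between compound 3 and compound 4 remains open. So does the outcome with a longer chain such as butoxycarbonyl, or with a carboxylic acid or an amide at this place.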